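Methyl in place of methoxy on a shared core

The source may report more compounds than this note shows. Statements on the series, on what has been measured and on what is new or still open speak of the compounds shown alone.

Three compounds share a core and carry a sugar and a five-membered ring; they differ at a six-membered ring bearing two nitrogens. In a functional assay on CEM-DNR-bulk cells (Homo sapiens), read by MTT assay, with a stated time of 72 h (on this read-out higher numbers stand for weaker inhibition and lower numbers for stronger inhibition), compound 1 `Cc1ncnc2c1c(-c1cccs1)cn2[C@@H]1O[C@H](CO)[C@@H](O)[C@H]1O` gives only a limit of the assay, > 20000 nM. Compound 2 `CNc1ncnc2c1c(-c1ccoc1)cn2[C@@H]1O[C@H](CO)[C@@H](O)[C@H]1O` likewise gives only a limit, > 20000 nM. Compound 3 `COc1ncnc2c1c(-c1ccoc1)cn2[C@@H]1O[C@H](CO)[C@@H](O)[C@H]1O` also gives only a limit, > 20000 nM. Within the data shown here, the one step that can be drawn, a step that the two limits leave unreadable from compound 2 to compound 3, cannot be read in size, since both ends are limits. All that is known is the limit of > 20000 nM in this assay, at which 3 of the 3 values shown sit.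

Compound 4 `Cc1ncnc2c1c(-c1ccoc1)cn2[C@@H]1O[C@H](CO)[C@@H](O)[C@H]1O` is made from compound 3 by the change (methyl in place of methoxy on an aromatic carbon). Among the measured compounds shown here, no measured step of the same kind exists; compound 1 carries the same methyl but a different five-membered ring, so its value shows only that a methyl there gave a limit. Compound 4 is therefore expected to give a limit as well, with an expected step that the limit leaves unreadable from compound 3 to compound 4, and an estimate of 30000 nM between 10000 nM and 100000 nM.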

Compound 4, half-maximal inhibitory concentration: > 20000 nM
Compound 4: only a limit was reported; the forecaster's own chance of this, stated with the estimate: 90%; the middle value lies beyond the limit too.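

No step can be read among compound 1, compound 2, compound 3 and compound 4, because each gives only a limit: the limit of > 20000 nM in this assay, at which 4 of the 4 values shown sit.

The compounds shown leave open whether methyl, methoxy, methylamino, furan-3-yl or thiophen-2-yl makes any difference to inhibition, as none gives an actual number.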